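Trifluoromethyl in place of hydrogen on compound 3

A few compounds are considered here, and "the series" means these few. Any claim that something is new, unique, unknown or untested is made for them only; others in the source may bear on it.

Compound 3 `O=C(NN=C(c1ccccn1)c1ccccn1)c1ccccc1` stands second highest of three numbers in an ADME assay on cells (Homo sapiens) for antiproliferative activity, read by MTT assay (on this read-out lower numbers stand for stronger inhibition and higher numbers for weaker inhibition), where compound 3 gives 3040 nM. Compound 1 `O=C(NN=C(c1ccccn1)c1ccccn1)c1cccs1` gives 950 nM, and compound 2 `Nc1ccc(C(=O)NN=C(c2ccccn2)c2ccccn2)cc1` gives 7640 nM. Among the measured compounds shown here, the step of a 3.2-fold higher number from compound 1 to compound 3 (0.51 log units; beyond the scatter) and the step of an 8.0-fold higher number from compound 1 to compound 2 (0.91 log units; beyond the scatter) come from exchanging the whole group on the carbonyl carbon, while the step of a 2.5-fold lower number from compound 2 to compound 3 (0.40 log units; beyond the scatter) is the only change made on the six-membered aromatic ring of carbon only. Compound 4 `O=C(NN=C(c1ccccn1)c1ccccn1)c1ccc(C(F)(F)F)cc1` differs from compound 3 by trifluoromethyl in place of hydrogen on an aromatic carbon. For the measured compounds named here, no measured step involves this group; the one substitution on that ring, amino to hydrogen, moved the number modestly, and in no fixed direction for a new group. The step of a 1.0-fold lower number from compound 3 to compound 4 (0.01 log units; within the scatter) is therefore expected to stay within the scatter. The estimate for compound 4 is 3000 nM, with a range from 1000 nM to 9000 nM.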

Compound 4, half-maximal inhibitory concentration: 240 nM
The estimate for compound 4 lay 13-fold (1.10 log units) above the measured number, and the stated range ends above it.
By their numbers in this assay, from the lowest: compound 4; then compound 1; then compound 3; then compound 2.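

In this assay this place on the ring proved far more sensitive than the amino-to-hydrogen change had shown: a 13-fold lower number from compound 3 to compound 4 (1.10 log units; beyond the scatter) is the largest step from hydrogen here, and it turns the ring from a modest site into a large one. Trifluoromethyl in place of amino spans still more, with a 32-fold lower number from compound 2 to compound 4 (1.50 log units; beyond the scatter) as the widest step in the series. Nothing measured accounts for the size of these steps.
As far as these compounds go, whether this drop is particular to trifluoromethyl stays open, since a chlorine atom, a methyl group or a nitrile in its place could show that. From the compounds shown here alone, it also stays open whether trifluoromethyl would act the same way elsewhere on the ring.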